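Swapping a fused bicycle for a small tetrazole

The source may hold more compounds than are shown below. What is called first, only, known or untested is meant among the compounds shown, and "the series" means these compounds.

Measured so far:
compound 1 `COc1ccc(CN(C(=O)CCCCSc2nc3ccccc3o2)c2cc(OC)c(OC)c(OC)c2)cc1` — 45600 nM
compound 2 `COc1ccc(CN(C(=O)CSc2nc3ccc(OC)cc3s2)c2cc(OC)c(OC)c(OC)c2)cc1` — 20200 nM

Both compounds share the same core and differ only in the group carried on the sulfur. In a functional assay on PC-3 cells (Homo sapiens) for antiproliferative activity, read by MTT assay, with a stated time of 48 h (a higher number here means a weaker inhibitor, a lower number a stronger inhibitor), compound 1 gives 45600 nM, while compound 2 gives 20200 nM. Of these two numbers compound 2 holds the lower one, and its gap to compound 1 lies beyond the usual scatter, so compound 2 is the stronger inhibitor of the pair. Compound 3 `COc1ccc(CN(C(=O)CSc2nnnn2C)c2cc(OC)c(OC)c(OC)c2)cc1` has not yet been measured. It differs from compound 2 in one place: 1-methyl-1H-tetrazol-5-yl in place of 6-methoxy-1,3-benzothiazol-2-yl on a sulfur. For the measured compounds named here, no measured pair shows what such an exchange does here, so the guidance is thin. The expectation is a step toward a weaker inhibitor in this assay, of moderate size, a 2.0-fold higher number from compound 2 to compound 3 (0.30 log units; within the scatter). Compound 3 is therefore estimated at 40000 nM, with a range from 12000 nM to 150000 nM.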

Compound 3, half-maximal inhibitory concentration: 10500 nM
Compound 3: the middle estimate sits 3.8-fold (0.58 log units) above what was measured; the whole stated range lies above it.
By their numbers in this assay, from the lowest: compounds 3 and 2 (each within the scatter of the next); then compound 1.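

In this assay the exchange comes to a 1.9-fold lower number from compound 2 to compound 3 (0.28 log units; within the scatter) and so leaves the two compounds indistinguishable. On this sulfur, a group of two fused aromatic rings and a single five-membered aromatic ring with far fewer heavy atoms therefore give readings that cannot be told apart, so for compound 2 at least, the six-membered aromatic ring and the methoxy group it carries are not needed to keep this level of activity. Nothing available explains why such different groups read alike.

Open, going by these compounds, is whether any ring is needed on the sulfur at all, which an open-chain group such as a carboxylic acid or an amine would test. Also open, on these data alone, is how the 1-methyl-1H-tetrazol-5-yl group would read on a longer chain.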